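Sulfonyl-linked urea series: ring swap on the sulfonyl sulfur

The source may hold more compounds than are shown below. What is called first, only, known or untested is meant among the compounds shown, and "the series" means these compounds.

Two compounds of the series carry a measured number. Compound 1 `Cc1ncccc1CNC(=O)Nc1ccc(S(=O)(=O)c2ccccc2)cc1` gives 146 nM in an assay on isolated protein for inhibition of Nicotinamide phosphoribosyltransferase (Homo sapiens), read by spectrophotometry, with stated times of 15 min and 30 min; a higher number here means a weaker inhibitor, a lower number a stronger inhibitor. Compound 2 `C[C@@H]1CN(S(=O)(=O)c2ccc(NC(=O)NCc3cccnc3)cc2)C[C@H](C)O1` gives 4 nM in this assay, the lowest of the two numbers shown; the nearest, compound 1, sits a good distance higher, well beyond the scatter. The two differ in more than one place, so no single step can be read from them.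

Compound 3 `CC1CNCCN(S(=O)(=O)c2ccc(NC(=O)NCc3cccnc3)cc2)C1` is the next point. It keeps the core of compound 2 and changes only the group on the sulfonyl sulfur: a group of 8 heavy atoms (6 carbon, 2 nitrogen; one seven-membered non-aromatic ring with 2 hetero atoms) in place of a group of 8 heavy atoms (6 carbon, 1 nitrogen, 1 oxygen; one six-membered non-aromatic ring with 2 hetero atoms), on a sulfonyl sulfur. The incoming group brings a hydrogen-bond donor where the 2,6-dimethylmorpholin-4-yl group had none.

No measured pair in the series isolates this kind of ring change, so the direction of the step in this assay cannot be drawn from shown data; a modest move toward a higher number, or no move beyond the scatter, is the expectation. Compound 3 is expected to give 10 nM in this assay, between 3 nM and 40 nM, a step of a 2.5-fold higher number from compound 2 to compound 3 (0.40 log units; beyond the scatter) that is expected to stay small.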

Compound 3, half-maximal inhibitory concentration: 100 nM
For compound 3 the middle estimate is 10-fold (1.00 log units) below the measured one; the measured number lies above the stated range.
By their numbers in this assay, from the lowest: compound 2; then compounds 3 and 1 (each within the scatter of the next).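

Going by these compounds alone, the group on the sulfonyl sulfur is the first place where a single change can be read, and it is not a tolerant one: in this assay the swap gives a 25-fold higher number from compound 2 to compound 3 (1.40 log units; beyond the scatter) on the shared core. The heavy-atom count of the group stays the same across the step, so that count alone does not track the number in this pair. The step, however, bundles several changes at once: ring size, oxygen replaced by nitrogen, a hydrogen-bond donor gained, and the defined stereocentres of the 2,6-dimethylmorpholin-4-yl group gone.

Which of these changes carries the step stays open, and an unsubstituted morpholine, a piperazine or an acetyl group on the ring nitrogen of the incoming group would help pull them apart. Also open is whether other groups on the sulfonyl sulfur, such as an open-chain dialkylamine, hold the number of compound 2, and no measurement shown here bears on the reason for the size of this step.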